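Chloro for trifluoromethyl on the methoxy-bearing ring

This account rests on a few compounds, and the source may have more. Where it says the series, first, only, none or still open, it means among the compounds named here.

Two members of the series have numbers. Compound 1 `O=C(c1cc(Cl)c(O)c(C(F)(F)F)c1)N1CS(=O)(=O)c2ccccc21` gives 2600 nM in an assay on tissue (RPTEC cells) for inhibition of solute carrier family 22 member 12 (Homo sapiens), read by scintillation counting, with stated times of 15 min and 2 h; on this read-out lower numbers stand for stronger inhibition and higher numbers for weaker inhibition. Compound 2 `COc1cc(C(=O)N2CS(=O)(=O)c3ccccc32)cc(C(F)(F)F)c1O` gives 17800 nM in this assay. Going by the values given here, the step between them, a 6.8-fold higher number from compound 1 to compound 2 (0.84 log units; beyond the scatter), is the only measured step. Compound 2 thus stands at the highest of the two numbers, and its nearest neighbour is compound 1.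

Compound 3 `COc1cc(C(=O)N2CS(=O)(=O)c3ccccc32)cc(Cl)c1O` is the next member to be measured. The change from compound 2 is chloro in place of trifluoromethyl on an aromatic carbon, on an aromatic carbon ortho to a hydroxy group and meta to a methoxy group. Among the compounds with values here, no measured step touches this position or this pair of groups: the single step on hand exchanges chloro and methoxy at another carbon, so it bears only indirectly, through a 6.8-fold higher number from compound 1 to compound 2 (0.84 log units; beyond the scatter), which shows that a change on this ring can move this assay by a modest amount. Within the data shown here, with no direct precedent, compound 3 is expected to give a number near that of compound 2, with wide uncertainty in either direction, estimated at 20000 nM (range 7000 nM to 60000 nM). The step of a 1.1-fold higher number from compound 2 to compound 3 (0.05 log units; within the scatter) is therefore expected to stay within the scatter.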

Compound 3, half-maximal inhibitory concentration: 4300 nM
Beside the measured number, compound 3's estimate is 4.7-fold (0.67 log units) above it; the measured number lies below the stated range.
By their numbers in this assay, from the lowest: compounds 1 and 3 (each within the scatter of the next); then compound 2.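

In this assay, the carbon ortho to a hydroxy group now has its first direct reading: with the methoxy group held constant, chloro in place of trifluoromethyl gives a 4.1-fold lower number from compound 2 to compound 3 (0.62 log units; beyond the scatter), so this position does respond to the change, and the step is beyond the scatter. The other new step, a 1.7-fold higher number from compound 1 to compound 3 (0.22 log units; within the scatter), is within the scatter, so a ring with chloro and trifluoromethyl and a ring with methoxy and chloro cannot be told apart here, and among the three compounds only compound 2, which holds methoxy and trifluoromethyl together, stands apart from the others. No measurement on hand bears on what lies behind either step.

The compounds shown place only chloro and trifluoromethyl on this carbon, so how a bromo, a methyl or a nitrile there would read in this assay remains open. The hydroxy group and the shared core are also unchanged across all three compounds, which leaves open what an amine or a carboxylic acid in place of that hydroxy group would do to the number.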